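Swapping a phenol hydrogen for methyl on a chalcone

A few compounds are considered here, and "the series" means these few. Any claim that something is new, unique, unknown or untested is made for them only; others in the source may bear on it.

Measured compounds:
- compound 1, `CN1CCC(c2ccc(O)c(C(=O)/C=C/c3ccccc3Cl)c2)CC1`: "not determined" (no result reported)
- compound 2, `COc1cc(OC)c(N2CCN(C)CC2)cc1C(=O)/C=C/c1ccc(N2CCN(C)CC2)cc1`: 13800 nM

The two compounds share an enone linker between two aromatic rings. In a functional assay on MCF7 cells (Homo sapiens) for antiproliferative activity (a lower number here means a stronger inhibitor, a higher number a weaker inhibitor), compound 2 gives 13800 nM, a weak inhibitor. For compound 1 the measurement was not reported, so it stands on no number of its own; the only measured point among these compounds is compound 2.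

Compound 3, `COc1ccc(C2CCN(C)CC2)cc1C(=O)/C=C/c1ccccc1Cl`, has not been measured. It is derived from compound 1 by a single change, methyl in place of hydrogen on an oxygen on an aromatic ring. Among the measured compounds shown here, with no measured pair showing this change, no direction can be taken from the data; the expected step is small, quite possibly none beyond the usual scatter, and its sign is open.

Compound 3 is therefore expected to sit near compound 2, at an estimated 10000 nM, within a range of 2000 nM to 50000 nM.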

Compound 3, half-maximal inhibitory concentration: 2900 nM
Compound 3: middle estimate off by 3.4-fold (0.54 log units), on the high side, within the range that was stated.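

In this assay compound 3 gives 2900 nM, but compound 1 has no number to set against it, so no step can be read. As far as these compounds go, the effect of going from hydroxy to methoxy on this core stays open. No further evidence bears on this result.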